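From 2,4-dichlorophenyl to 3,4-dichlorophenyl in a cell assay

The source may report more compounds than this note shows. Statements on the series, on what has been measured and on what is new or still open speak of the compounds shown alone.

Measured so far in a functional assay on HepG2 cells (Homo sapiens) for cytotoxicity, read by MTT assay, with a stated time of 24 h; a lower number here means a stronger inhibitor, a higher number a weaker inhibitor:
- compound 1 `CN1C/C(=C\c2cccc([N+](=O)[O-])c2)C(=O)/C(=C/c2ccccc2F)C1` gives 1080 nM
- compound 2 `CN1C/C(=C\c2ccc(F)cc2)C(=O)/C(=C/c2cccc([N+](=O)[O-])c2)C1` gives 9340 nM
- compound 3 `CN1C/C(=C\c2cccc([N+](=O)[O-])c2)C(=O)/C(=C/c2ccc(Cl)cc2Cl)C1` gives 4800 nM

Compound 3 sits level with compound 2 and clearly above compound 1, as a 1.9-fold lower number from compound 2 to compound 3 (0.29 log units; within the scatter) and a 4.4-fold higher number from compound 1 to compound 3 (0.65 log units; beyond the scatter) show.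

Compound 4 `CN1C/C(=C\c2cccc([N+](=O)[O-])c2)C(=O)/C(=C/c2ccc(Cl)c(Cl)c2)C1` keeps the shared core and changes one group: 3,4-dichlorophenyl in place of 2,4-dichlorophenyl on a double-bonded chain carbon bound to a double-bonded ring carbon. In words, this is 3,4-dichlorophenyl in place of 2,4-dichlorophenyl on a double-bonded chain carbon bound to a double-bonded ring carbon.

Going by the values given here, no measured step makes this exact change. The closest guide is the pair of fluorophenyl compounds, with an 8.6-fold higher number from compound 1 to compound 2 (0.94 log units; beyond the scatter), where a change of halogen position alone shifted the number. The dichlorophenyl compound 3 already lies at the high end, however, so little room for a similar rise is assumed. In this assay, only a small upward step is therefore expected, probably none beyond the scatter.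

The expected step is a 1.1-fold higher number from compound 3 to compound 4 (0.06 log units; within the scatter).

For compound 4 the estimated value is 5500 nM, with an expected range from 2000 nM to 15000 nM.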

Compound 4, half-maximal inhibitory concentration: 5960 nM
The estimate for compound 4 lay 1.1-fold (0.03 log units) below the measured number; low and high end bracket the measured number.
By their numbers in this assay, from the lowest: compound 1; then compounds 3, 4 and 2 (each within the scatter of the next).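

In this assay, moving one chlorine so that 3,4-dichlorophenyl replaces 2,4-dichlorophenyl gives only a small step (a 1.2-fold higher number from compound 3 to compound 4 (0.09 log units; within the scatter)), so this change of chlorine position leaves the number within the scatter. Compound 4 also stays within the scatter of the 4-fluorophenyl compound (a 1.6-fold lower number from compound 2 to compound 4 (0.20 log units; within the scatter)), while the 2-fluorophenyl compound keeps the lowest number of the four, now against a further dichlorophenyl compound (a 5.5-fold higher number from compound 1 to compound 4 (0.74 log units; beyond the scatter)). No measurement given here offers a reason for these numbers.

A 2-chlorophenyl group at this place would help show whether the low number of compound 1 goes with the 2-fluorophenyl group alone or with any single halogen in that position. Going by these compounds, how a phenyl ring carrying a methoxy group or an amine would compare remains open.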